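Series notes: the step from compound 2 to compound 4

The compounds below may be only part of what the source reports. "The series", "measured", "known", "first", "only" and "open" are said of these compounds alone.

Measured so far in an ADME assay on MT4 cells (Homo sapiens) for cytotoxicity, read by MTT assay; a lower number here means that less compound is tolerated, a higher number that more compound is tolerated:
- compound 1 `Cc1cc(C)cc(S(=O)(=O)c2c(C(=O)NCC(=O)NCc3ccncc3)[nH]c3ccc(Cl)cc23)c1` gives > 48900 nM (a limit)
- compound 2 `Cc1cc(C)cc(S(=O)(=O)c2c(C(=O)NCc3cccc(N)c3)[nH]c3ccc(Cl)cc23)c1` gives > 53400 nM (a limit)
- compound 3 `Cc1cc(C)cc(S(=O)(=O)c2c(C(=O)NC(C)C(=O)NC(C)c3ccccc3)[nH]c3ccc(Cl)cc23)c1` gives 21700 nM (a number)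

Compound 2 is known only by the limit > 53400 nM and has no number in this assay at all. Compound 4 `Cc1cc(C)cc(S(=O)(=O)c2c(C(=O)NC(c3ccc(Cl)cc3)C3CC3)[nH]c3ccc(Cl)cc23)c1` keeps the shared core and changes the group on an amide-type nitrogen, where 3-aminobenzyl leaves: a group of 11 heavy atoms (10 carbon, 1 chlorine; one three-membered non-aromatic ring of carbon only, one six-membered aromatic ring of carbon only) in place of a group of 8 heavy atoms (7 carbon, 1 nitrogen; one six-membered aromatic ring of carbon only), on an amide-type nitrogen. Within the data shown here, the only measured step that bears on this change is a step that the two limits leave unreadable from compound 1 to compound 2, and it has no readable size, so it sets no scale. Among the measured compounds shown here, compound 3 also differs from compound 2 in the group on that nitrogen, and compound 3 gives 21700 nM, the only number available. On that single value, a move towards less compound tolerated is expected, with a real chance that the result stays at a limit. The size of the expected change is estimated as an at least 2.9-fold lower number from compound 2 to compound 4 (0.47 log units; beyond the scatter) and remains loosely founded. The estimated value in this assay for compound 4 is 18000 nM, expected to fall between 6000 nM and 50000 nM if a number is reported.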

Compound 4, half-maximal cytotoxic concentration: > 47300 nM
Compound 4: no number, only a limit (the forecaster's own chance of this, stated with the estimate: 35%); at least 2.6-fold (0.41 log units) between middle value and limit.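

In this assay compound 4 gives only a limit, > 47300 nM. The steps from compound 1 and from compound 2 to compound 4 therefore cannot be read. The compounds shown leave open how far the values of compound 1, compound 2 and compound 4 differ with the group on the amide-type nitrogen.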